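A few compounds are considered here, and "the series" means these few. Any claim that something is new, unique, unknown or untested is made for them only; others in the source may bear on it.

Measured in a functional assay on HCT-116 cells (Homo sapiens) for cytotoxicity, read by MTT assay, with a stated time of 48 h, in the presence of a further agent that is not named here; on this read-out higher numbers stand for an effect only at larger amounts of compound and lower numbers for an effect already at smaller amounts:
- compound 1 `Cc1c(Cc2ccccc2)c(NNC(=O)Nc2cc(Cl)nc(Cl)c2)nc2c1cnn2C`: 13600 nM
- compound 2 `Cc1nn(C)c2nc(NNC(=O)Nc3cc(Cl)nc(Cl)c3)cc(C3CC3)c12`: 67700 nM
- compound 3 `COc1ccc(-c2cc(NNC(=O)Nc3cc(Cl)nc(OC(C)C)c3)nc3c2cnn3C)cc1`: 39800 nM

Compound 2 at 67700 nM sits level with compound 3 at 39800 nM, within the scatter. Its number is higher than that of compound 1 at 13600 nM, a gap beyond the scatter.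

Compound 4 `CCCc1cc(NNC(=O)Nc2cc(Cl)nc(Cl)c2)nc2c1c(C)nn2C` differs from compound 2 by one change: propyl in place of cyclopropyl on an aromatic carbon. Going by the values given here, no measured pair isolates this change, so compound 2 at 67700 nM is the only anchor. The estimated 1.4-fold lower number from compound 2 to compound 4 (0.13 log units; within the scatter) is small, towards a lower number in this assay, and no step beyond the scatter is expected. For compound 4 the expected value is 50000 nM, with an estimated range of 18000 nM to 110000 nM.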

Compound 4, half-maximal effective concentration: 72200 nM
Compound 4: middle estimate off by 1.4-fold (0.16 log units), on the low side; measured number inside the range.
By their numbers in this assay, from the lowest: compound 1; then compounds 3, 2 and 4 (each within the scatter of the next).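

Swapping in propyl for cyclopropyl on this aromatic carbon, opposite the ring nitrogen, gives a 1.1-fold higher number from compound 2 to compound 4 (0.03 log units; within the scatter) in this assay. At this position, then, the three-membered ring is not needed for the number seen, and an open chain with the same count of heavy atoms reads alike. No supporting data bear on why the two groups read alike.

Still open, on these data alone, is whether an amine, a carboxylic acid or a longer chain at this position would shift the number beyond the scatter. As far as these compounds go, whether the swap reads the same with the isopropoxy group of compound 3 on the other ring also remains open.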